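The source may hold more compounds than are shown below. What is called first, only, known or untested is meant among the compounds shown, and "the series" means these compounds.

In a functional assay on ZR-75-1 cells (Homo sapiens) for cytotoxicity, read by sulforhodamine B assay, with a stated time of 3 days (a lower number here means that less compound is needed, a higher number that more compound is needed for the effect), compound 1 `Cc1coc(-c2ccc3c(c2O)CCCC3(C)C)c1C(=O)O` gives 1.7 uM and compound 3 `CCc1cccc2c(O)c(-c3occ(C)c3C(=O)O)ccc12` gives 1 uM, two values within the scatter of each other, while compound 2 `COc1c(-c2occ(C)c2C(=O)O)ccc2c1CCCC2(C)C` gives 41.4 uM. Compound 4 `Cc1coc(-c2ccc3c(c2O)CCCC3(C)C)c1CO` keeps the core of compound 1 and has hydroxymethyl in place of carboxy on an aromatic carbon. For the measured compounds named here, the only measured step, a 24-fold higher number from compound 1 to compound 2 (1.39 log units; beyond the scatter), is large, but it is methyl in place of hydrogen on an oxygen on an aromatic ring, so it lies elsewhere on the structure. Going by the values given here, no measured step covers the carboxy group. A moderate move towards a higher number is therefore expected in this assay, with wide uncertainty. The estimated step is a 2.9-fold higher number from compound 1 to compound 4 (0.47 log units; beyond the scatter). For compound 4 the estimated value is 5 uM, with an expected range of 1.5 uM to 20 uM.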

Compound 4, concentration for half-maximal effect: 25.5 uM
Compound 4: middle estimate off by 5.1-fold (0.71 log units), on the low side; the measured number lies above the stated range.
By their numbers in this assay, from the lowest: compounds 3 and 1 (each within the scatter of the next); then compounds 4 and 2 (each within the scatter of the next).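

In this assay, for the compounds shown here, the step of a 15-fold higher number from compound 1 to compound 4 (1.18 log units; beyond the scatter) is large and gives the first reading at the carboxy position, showing that this place on the five-membered aromatic ring is sensitive to this change. Hydroxymethyl and carboxy have equal hydrogen-bond donor and acceptor counts and no net charge, so these counts do not account for the difference. Nothing available gives a cause for this step. From the compounds shown here alone, a methyl ester or a primary amide at this position remains open. So does whether the same replacement on compound 3 gives a step of similar size.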